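The compounds below may be only part of what the source reports. "The series", "measured", "known", "first", "only" and "open" are said of these compounds alone.

Compound 1 `COc1cccc(CNCc2c(C(=O)O)n(Cc3ccccc3)c3cc(C(C)C)ccc23)c1` serves as the starting point. In a functional assay on Bel-7402 cells (Homo sapiens) for antiproliferative activity, read by MTT assay, with a stated time of 72 h (on this read-out higher numbers stand for weaker inhibition and lower numbers for stronger inhibition), compound 1 gives 5900 nM, and the two measured companions sit within the scatter of that number. Compound 2 `COc1cccc(CNCc2c(C(=O)O)n(Cc3ccc(O)cc3)c3cc(C(C)C)ccc23)c1` gives 7080 nM in this assay, a step of a 1.2-fold higher number from compound 1 to compound 2 (0.08 log units; within the scatter). Compound 3 `COc1cccc(CNCc2c(C(=O)O)n(Cc3ccc(C)cc3)c3cc(C(C)C)ccc23)c1` gives 5920 nM, a step of a 1.0-fold higher number from compound 1 to compound 3 (0.00 log units; within the scatter), and the step between them is a 1.2-fold lower number from compound 2 to compound 3 (0.08 log units; within the scatter). Compound 4 `COc1cccc(CNCc2c(C(=O)O)n(Cc3ccccc3)c3cc(C)ccc23)c1` differs from compound 1 by methyl in place of isopropyl on an aromatic carbon. For the measured compounds named here, none of the measured steps touches this group, and all three stayed within the scatter, so they offer no direction for the change. Compound 4 is therefore expected to show a step of about no change at the digits printed from compound 1 to compound 4 (within the scatter). Compound 4 is estimated at 5900 nM, with a range from 2500 nM to 14000 nM.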

Compound 4, half-maximal inhibitory concentration: 12500 nM
For compound 4 the middle estimate is 2.1-fold (0.33 log units) below the measured one, and the stated range covers the measured number.
By their numbers in this assay, from the lowest: compounds 1, 3, 2 and 4 (each within the scatter of the next, the first and the last beyond it).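

In this assay, the change from isopropyl to methyl gives a 2.1-fold higher number from compound 1 to compound 4 (0.33 log units; beyond the scatter), the first step shown that lies beyond the scatter. This position on the shared core therefore responds to substitution, whereas the hydroxy and methyl changes elsewhere in compounds 2 and 3 left the number within the scatter of compound 1. No measurement shown accounts for this step.

From the compounds shown here alone, it remains open how an ethyl, a tert-butyl or a methoxy group would behave at this place. A single step also cannot show whether the number follows the carbon count of the group.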